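The source may hold more compounds than are shown below. What is called first, only, known or untested is meant among the compounds shown, and "the series" means these compounds.

Of the compounds shown here, three have been tested so far, and all three stop at the same point. Compound 1 `S=C(N/N=C/c1cccs1)Nc1cccc2ccccc12` gives > 100000 nM in a functional assay on PC-3 cells (Homo sapiens) for inhibition, read by sulforhodamine B assay, with a stated time of 48 h (a lower number here means a stronger inhibitor of growth, a higher number a weaker inhibitor of growth), which is a limit of the assay rather than a number. Compound 2 `CCc1ccc(NC(=S)N/N=C/c2cccs2)cc1` likewise gives only a limit in this assay, > 100000 nM. Compound 3 `C=CCNC(=S)N/N=C/c1cccs1` reaches the same limit in this assay, > 100000 nM. Within the data shown here, compound 2 therefore stands nowhere above or below its neighbours: every value shown sits at the limit (the limit of > 100000 nM in this assay, at which 3 of the 3 values shown sit), so no order among the three can be drawn, and no measured step between any two of them exists.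

The unmeasured compound 4 `S=C(N/N=C/c1cccs1)Nc1ccc(Cl)cc1` differs from compound 2 in a single place (chloro in place of ethyl on an aromatic carbon). Among the measured compounds shown here, with no measured step to lean on, the step from compound 2 to compound 4 is expected to be none beyond the scatter, a number no higher from compound 2 to compound 4 (the limit leaves the size open). Compound 4 is accordingly expected to give about 100000 nM in this assay, with a range from 30000 nM to 300000 nM, and most likely the assay will again report only a limit.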

Compound 4, concentration for 50% growth inhibition: > 100000 nM
Compound 4 gave a limit, no number; the forecaster's own chance of this, stated with the estimate: 80%; the middle value sits exactly at the limit.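

Among these compounds, compound 4 also gives only a limit, > 100000 nM, so no step from compound 2 to compound 4 can be read, and the effect of chloro in place of ethyl stays unknown. How these four compounds rank against one another in this assay remains open: the limit of > 100000 nM in this assay, at which 4 of the 4 values shown sit.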